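A few compounds are considered here, and "the series" means these few. Any claim that something is new, unique, unknown or untested is made for them only; others in the source may bear on it.

Measured compounds and their results:

compound 1, `Cc1cc(=O)oc2ccc(OCC(O)CN3CCN(c4ccccc4)CC3)cc12`: 0.0085 ug/mL
compound 2, `O=c1cc(-c2ccccc2)c2ccc(OCC(O)CN3CCNCC3)cc2o1`: 0.0086 ug/mL
compound 3, `O=c1cc(-c2ccccc2)c2ccc(OCC(O)CN3CCN(c4ccccc4)CC3)cc2o1`: 0.0083 ug/mL

In a functional assay on ileum for antagonist activity at histamine H1 receptor (Cavia porcellus), tested at 1 mg/mL (a higher number here means that more compound is needed for the effect, a lower number that less compound is needed), compound 3 gives 0.0083 ug/mL, the smallest of the three numbers, but its gaps to compound 1 and compound 2 lie within the usual scatter, so the three compounds cannot be told apart on these results. For the measured compounds named here, the one single-point step among them, a 1.0-fold lower number from compound 2 to compound 3 (0.02 log units; within the scatter), put a whole phenyl onto the ring amine and changed nothing beyond the scatter. Compound 4, `COc1ccccc1N1CCN(CC(O)COc2ccc3c(-c4ccccc4)cc(=O)oc3c2)CC1`, is compound 3 with one further change: methoxy in place of hydrogen on an aromatic carbon. Going by the values given here, no measured pair shows the effect of a methoxy anywhere, so the only guide is that the larger change of adding the phenyl itself left the number where it was. A small decoration on that same phenyl is therefore expected to do little as well, and the number of compound 4 is estimated to stay close to that of compound 3. For compound 4 the expected result in this assay is 0.0085 ug/mL, with a plausible range from 0.004 ug/mL to 0.02 ug/mL. The expected step is a 1.0-fold higher number from compound 3 to compound 4 (0.01 log units; within the scatter), which is no change beyond the scatter.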

Compound 4, half-maximal effective concentration: 0.0089 ug/mL
For compound 4 the middle estimate is 1.0-fold (0.02 log units) below the measured one; measured number inside the range.
By their numbers in this assay, from the lowest: compounds 3, 1, 2 and 4 (each within the scatter of the next).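

In this assay, methoxy in place of hydrogen on an aromatic carbon, ortho to a large group, gives a 1.1-fold higher number from compound 3 to compound 4 (0.03 log units; within the scatter), so this carbon of the phenyl takes a methoxy with no change that can be told from the scatter. Until now the phenyl on the ring amine had been seen only bare; with this result, a substituted phenyl has been seen there as well. The whole 2-methoxyphenyl in place of hydrogen on that amine nitrogen gives a 1.0-fold higher number from compound 2 to compound 4 (0.01 log units; within the scatter), so among these compounds neither the phenyl nor the 2-methoxyphenyl moves the number beyond the scatter.

Since every step here stays within the scatter, the compounds shown do not yet reveal any change at this nitrogen or on its phenyl that the number responds to. Still open, on these data alone, is whether a chlorine or a carboxylic acid on that phenyl, or a benzyl group or a longer alkyl chain on the nitrogen, would move the number beyond the scatter. No measurement is available that would explain why the number holds steady across these changes.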